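This account rests on a few compounds, and the source may have more. Where it says the series, first, only, none or still open, it means among the compounds named here.

Of the compounds shown here, three sharing one core have been measured in a functional assay on M21 cells (Homo sapiens) for antiproliferative activity, with a stated time of 48 h; on this read-out lower numbers stand for stronger inhibition and higher numbers for weaker inhibition. Compound 1 `O=C(NCCCCl)Nc1ccc(I)cc1` carries an iodo group on an aromatic carbon; compound 1 gives > 100000 nM, which is a limit of the assay rather than a number. Compound 2 `CC(C)(C)c1ccc(NC(=O)NCCCCl)cc1` carries a tert-butyl group in its place, and compound 2 gives 35000 nM. Compound 3 `CCCCCc1cccc(NC(=O)NCCCCl)c1` carries a pentyl chain on its aromatic ring, and compound 3 gives 24000 nM. For the measured compounds named here, the one step between compounds that differ in a single place is an at least 2.8-fold lower number from compound 1 to compound 2 (0.45 log units; beyond the scatter); it rests on (the limit of > 100000 nM in this assay, at which 1 of the 3 values shown sits). Among the two plain numbers, compound 2 stands highest, with compound 3 the nearest at a gap within the usual scatter, while the third value is a limit.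

The next compound, compound 4 `C=CC(=O)Nc1ccc(C(C)(C)C)cc1`, differs from compound 2 in one place: vinyl in place of (3-chloropropyl)amino on a carbonyl carbon. Going by the values given here, no measured step touches this part of the molecule; the only measured step exchanges a group on the aromatic ring and leaves the carbonyl carbon untouched. The measured compounds thus give no basis for expecting a step in either direction beyond the scatter. The estimate for compound 4 is therefore 25000 nM, with a range from 4000 nM to 100000 nM. This estimate means an expected step of a 1.4-fold lower number from compound 2 to compound 4 (0.15 log units; within the scatter).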

Compound 4, half-maximal inhibitory concentration: 22000 nM
Compound 4: the middle estimate sits 1.1-fold (0.06 log units) above what was measured; the range from low to high includes it.
By their numbers in this assay, from the lowest: compounds 4, 3 and 2 (each within the scatter of the next). At a limit, above all of these: compound 1.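

At the carbonyl carbon, which all three earlier compounds shared unchanged, this assay shows a 1.6-fold lower number from compound 2 to compound 4 (0.20 log units; within the scatter), so swapping (3-chloropropyl)amino for vinyl leaves the two compounds indistinguishable on this read-out. With the tert-butyl group held constant, this pair shows that the (3-chloropropyl)amino group, and the hydrogen-bond donor counted within it, can be replaced by vinyl without a change that stands out from the scatter, although this finding rests on a single pair and does not establish a pattern. For the compounds shown here, nothing measured so far accounts for this outcome, as the only available evidence concerns the limit reached by compound 1 and has no bearing on compound 2 or compound 4.

The compounds shown leave open how a plain ethyl group, an unsubstituted propylamino chain or a longer chloroalkylamino chain would read at this carbonyl carbon, and so which feature of either group matters, if any does. They also leave open whether the same exchange would give a similar result when made on compound 3, which carries a pentyl chain on its aromatic ring instead of tert-butyl.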